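Ester to carbamate on the shared core: working notes

The source may hold more compounds than are shown below. What is called first, only, known or untested is meant among the compounds shown, and "the series" means these compounds.

Measured so far:
compound 1 `[C-]#[N+]Cc1c(C)nc2c(OCc3ccccc3)cccn12` — 96%
compound 2 `CCSCc1c(C)nc2c(OCc3ccccc3)cccn12` — 36%
compound 3 `CC(=O)OCc1c(C)nc2c(OCc3ccccc3)cccn12` — 88%

All numbers come from a functional assay on the whole organism with Rattus norvegicus as the target, with a stated time of 4 h, at a dose of 40 mg/kg by the intraperitoneal route; a lower number here means less inhibition, a higher number more inhibition at the dose given (going by the name of the read-out). Compound 3 stands second highest of the three; its nearest is compound 1, with a number 8 percentage points lower from compound 1 to compound 3 (within the scatter), and its furthest is compound 2, with a number 52 percentage points higher from compound 2 to compound 3 (beyond the scatter).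

Compound 4 `Cc1nc2c(OCc3ccccc3)cccn2c1COC(=O)N(C)C` differs from compound 3 by dimethylamino in place of methyl on a carbonyl carbon. Among the measured compounds shown here, no measured step touches the carbonyl carbon: the two measured steps alter the group on the saturated chain carbon bound to an aromatic carbon, and a number 60 percentage points lower from compound 1 to compound 2 (beyond the scatter) shows that group matters there. For the measured compounds named here, for a change one bond further out, on the acetyl itself, no comparable step exists, so the expected step is none beyond the scatter, a number 4 percentage points lower from compound 3 to compound 4 (within the scatter). Compound 4 is therefore estimated at 84%, within 62% to 98%.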

Compound 4, a percentage reported as inhibition, in the whole organism at one dose (the size of the read-out at that dose, not a potency): 75%
Estimate against measurement, compound 4: 9 percentage points above, within the range that was stated.
By their numbers in this assay, from the lowest: compound 2; then compound 4; then compounds 3 and 1 (each within the scatter of the next).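

In this assay the carbonyl carbon proves to be a place that responds: dimethylamino in place of methyl gives a number 13 percentage points lower from compound 3 to compound 4 (beyond the scatter) as a modest step. The (dimethylcarbamoyl)oxy group also stands apart from both other groups on the saturated chain carbon, with a number 39 percentage points higher from compound 2 to compound 4 (beyond the scatter) and with a number 21 percentage points lower from compound 1 to compound 4 (beyond the scatter) while acetoxy gave only a number 8 percentage points lower from compound 1 to compound 3 (within the scatter) in the same comparison. No measurement on hand explains the step at the carbonyl carbon.

From the compounds shown here alone, whether the step follows from the nitrogen itself or from its two methyl groups stays open. A methylamino, amino or methoxy group on the carbonyl carbon would bear on that.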